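The compounds below may be only part of what the source reports. "The series", "measured", "known", "first", "only" and "open" are said of these compounds alone.

Of the compounds shown here, three sharing one core have been measured in a functional assay on HeLa cells (Homo sapiens) for cytotoxicity, read by WST assay, with a stated time of 48 h; on this read-out higher numbers stand for weaker inhibition and lower numbers for stronger inhibition. Compound 1 (`COc1ccc([C@H](O)[C@H]2CO[C@H](c3ccc(OC)c(OC)c3)[C@@H](C/C=C/c3ccc(OC)c(OC)c3)C2)cc1`) gives 46000 nM, compound 2 (`COc1cccc([C@H](O)[C@H]2CO[C@H](c3ccc(OC)c(OC)c3)[C@@H](C/C=C/c3ccc(OC)c(OC)c3)C2)c1`) gives 21200 nM, and compound 3 (`COc1cccc([C@H](O)[C@H]2CO[C@@H](c3ccc(OC)c(OC)c3)[C@H](C/C=C/c3ccc(OC)c(OC)c3)C2)c1`) gives 18600 nM. Compound 3 thus stands level with compound 2, and the numbers of both lie under that of compound 1.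

Compound 4 (`COc1ccc([C@H](O)[C@H]2CO[C@@H](c3ccc(OC)c(OC)c3)[C@H](C/C=C/c3ccc(OC)c(OC)c3)C2)cc1`) has not yet been measured. Its difference from compound 3 is 4-methoxyphenyl in place of 3-methoxyphenyl on a saturated chain carbon bound to an oxygen on a saturated carbon and a saturated ring carbon.

For the measured compounds named here, two measured steps bear on this change. The same exchange, run the opposite way, appears as a 2.2-fold lower number from compound 1 to compound 2 (0.34 log units; beyond the scatter), which is modest. The other step, a 1.1-fold lower number from compound 2 to compound 3 (0.06 log units; within the scatter), involves only the configuration as drawn (the fact that compounds 2 and 3 differ only in the configuration as drawn), and it stays within the scatter. Compound 4 relates to compound 3 as compound 1 relates to compound 2, so the first step is expected to carry over in reverse, despite the different configuration. The expected step is a 2.2-fold higher number from compound 3 to compound 4 (0.33 log units; beyond the scatter), a modest move toward a higher number in this assay. For compound 4 the estimated value is 40000 nM, with an expected range from 20000 nM to 80000 nM.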

Compound 4, half-maximal inhibitory concentration: 32200 nM
For compound 4 the middle estimate is 1.2-fold (0.09 log units) above the measured one, and the stated range covers the measured number.
By their numbers in this assay, from the lowest: compounds 3, 2, 4 and 1 (each within the scatter of the next, the first and the last beyond it).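

On the second configuration, the exchange of 3-methoxyphenyl for 4-methoxyphenyl on this saturated chain carbon reads in this assay as a 1.7-fold higher number from compound 3 to compound 4 (0.24 log units; within the scatter), so the change that lay beyond the scatter on the first configuration does not do so here. The two readings still point the same way and do not separate from each other, which gives the exchange a consistent, if small, size across both configurations: the same change on two cores in this assay, a 2.2-fold lower number (0.34 log units; beyond the scatter) from compound 1 to compound 2 and a 1.7-fold lower number (0.24 log units; within the scatter) from compound 4 to compound 3, 1.3-fold (0.10 log units) apart, within the scatter of two such steps. For the compounds shown here, the indifference to configuration that the earlier compounds showed only with 3-methoxyphenyl now also appears with 4-methoxyphenyl, as a 1.4-fold lower number from compound 1 to compound 4 (0.15 log units; within the scatter), a step within the scatter: the fact that compounds 1 and 4 differ only in the configuration as drawn.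

The compounds shown carry only a methoxy group on this phenyl ring, so it remains open whether a 4-hydroxyphenyl or a 4-aminophenyl group at the same place would shift the number in this assay further than the exchange seen here. The saturated chain carbon bound to the oxygen is also drawn alike in all four compounds, which leaves the effect of its opposite configuration open.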